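This account rests on a few compounds, and the source may have more. Where it says the series, first, only, none or still open, it means among the compounds named here.

Compound 1 `COc1ccc(C[C@H]2COC(=O)[C@@H]2Cc2ccc(OCc3cn(-c4cccc(Cl)c4)nn3)c(OC)c2)cc1OC` in an ADME assay on HeLa cells (Homo sapiens) for cytotoxicity, read by MTT assay (on this read-out higher numbers stand for weaker inhibition and lower numbers for stronger inhibition), gives 493000 nM.
Compound 2 `COC(=O)[C@@H](NC(=O)CCC(=O)Oc1ccc(C[C@H]2C(=O)OC[C@@H]2Cc2ccc(OC)c(OC)c2)cc1OC)C(C)C` in this assay gives 64000 nM.

Of the two measured compounds, compound 1 stands at the higher number in this assay, and the gap to compound 2 is beyond the scatter, so compound 1 is the weaker inhibitor of the pair. Compound 3 `COc1ccc(C[C@H]2COC(=O)[C@@H]2Cc2ccc(OCc3cn(Cc4ccccc4)nn3)c(OC)c2)cc1OC` shares the core of compound 1 and differs from it in one place: benzyl in place of 3-chlorophenyl on an aromatic nitrogen. Among the compounds with values here, no measured pair shows what such an exchange does in this assay, so there is no step to lean on. With the core kept and the change confined to the group on the triazole nitrogen, no step beyond the scatter is expected from compound 1 to compound 3 in either direction, that is, a step of about a 1.2-fold lower number from compound 1 to compound 3 (0.09 log units; within the scatter). Compound 3 is therefore estimated at 400000 nM in this assay, with a range from 150000 nM to 1000000 nM.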

Compound 3, half-maximal inhibitory concentration: 346000 nM
The estimate for compound 3 lay 1.2-fold (0.06 log units) above the measured number; the measured number falls inside the stated range.
By their numbers in this assay, from the lowest: compound 2; then compounds 3 and 1 (each within the scatter of the next).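

In this assay, benzyl in place of 3-chlorophenyl on an aromatic nitrogen gives a 1.4-fold lower number from compound 1 to compound 3 (0.15 log units; within the scatter), the first step read at this position. Both groups carry one six-membered aromatic ring of carbon only, and in this one pair the exchange of the ring-bearing group leaves the number within the scatter. Nothing available bears on why this exchange gives a step of this size.

From the compounds shown here alone, whether this holds for other groups at this nitrogen stays open, for instance an unsubstituted phenyl, which would separate the chlorine from the added carbon, or a longer chain ending in an amine or a carboxylic acid. Compound 2 differs from compound 1 and compound 3 in more than one place, so what its changes contribute also remains unresolved.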